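Carboxy for Ethyl on an Amidine-Bearing Protease Inhibitor

The source may report more compounds than this note shows. Statements on the series, on what has been measured and on what is new or still open speak of the compounds shown alone.

Measured so far:
compound 1 `N=C(N)c1ccc(CNC(=O)[C@@H]2CCCN2C(=O)[C@@H](CC(=O)O)NS(=O)(=O)Cc2ccccc2)cc1`: 1430 nM
compound 2 `CCC[C@H](NCc1ccc(C(=N)N)cc1)C(=O)[C@@H](CCCNC(=N)N)NS(=O)(=O)Cc1ccccc1`: 15 nM

The two measured compounds were tested in an assay on isolated protein for inhibition of transmembrane protease serine 11D (Homo sapiens), read by fluorescence; a lower number here means a stronger inhibitor, a higher number a weaker inhibitor. Compound 1 gives 1430 nM there, while compound 2 gives 15 nM. Compound 2 thus stands at the lowest of the two numbers, and compound 1 lies far above it, well beyond the scatter of repeated measurements. The two differ in many places at once, so their gap says nothing about any single group.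

Compound 3 `N=C(N)NCCC[C@@H](NS(=O)(=O)Cc1ccccc1)C(=O)[C@H](CC(=O)O)NCc1ccc(C(=N)N)cc1` has not yet been measured in this assay. It differs from compound 2 in one place: carboxy in place of ethyl on a saturated chain carbon, two bonds along the chain from an amine nitrogen and a carbonyl carbon. For the measured compounds named here, no measured pair shows this change in isolation, and compound 1, although it carries a carboxy, rests on a different core, so it offers no direct guide.

With nothing closer to lean on, the step from compound 2 to compound 3 is expected to run toward a higher number, a 4.0-fold higher number from compound 2 to compound 3 (0.60 log units; beyond the scatter), modest in size and possibly beyond the scatter. Compound 3 is therefore estimated at 60 nM in this assay, within a range of 15 nM to 300 nM.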

Compound 3, inhibition constant: 422 nM
The estimate for compound 3 lay 7.0-fold (0.85 log units) below the measured number; the whole stated range lies below it.
By their numbers in this assay, from the lowest: compound 2; then compound 3; then compound 1.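

In this assay, carboxy in place of ethyl on a saturated chain carbon, two bonds along the chain from an amine nitrogen and a carbonyl carbon, gives a 28-fold higher number from compound 2 to compound 3 (1.45 log units; beyond the scatter), a large step. For the compounds shown here, this is the first change seen in isolation, and it shows that the position is far from indifferent to what it carries: this one replacement, read equally as propyl to carboxymethyl, moves the number well beyond the scatter while the rest of the structure stays the same. Nothing at hand explains why the step is this large.

With only two groups compared at this carbon, the compounds shown cannot tell whether the higher number belongs to the carboxy specifically or would also follow from other replacements for the propyl chain, such as a methyl ester, a primary amide or a hydroxymethyl. They also leave open whether a longer alkyl chain or a ring such as cyclohexyl at the same place would give a number lower or higher than that of compound 2, and compound 1, which differs from both in several places, cannot settle either question.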